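Sulfur to selenium on a benzylic cyanide group

This account rests on a few compounds, and the source may have more. Where it says the series, first, only, none or still open, it means among the compounds named here.

Two compounds have numbers in a functional assay on PC-3 cells (Homo sapiens) for cytotoxicity, read by MTT assay, with a stated time of 72 h; a lower number here means a stronger inhibitor of growth, a higher number a weaker inhibitor of growth. Compound 1, `O=C1c2ccccc2C(=O)N1C[SeH]`, gives 6400 nM. Compound 2, `N#CSCc1ccc(-n2cccc2)cc1`, gives 14100 nM, the higher of the two numbers; the gap between compound 2 and compound 1 lies beyond the usual scatter, so compound 2 is the weaker of the pair in this assay.

Compound 3, `N#C[Se]Cc1ccc(-n2cccc2)cc1`, has not yet been measured. It differs from compound 2 in one place: a group of 3 heavy atoms (1 carbon, 1 nitrogen, 1 selenium; no ring) in place of a group of 3 heavy atoms (1 carbon, 1 nitrogen, 1 sulfur; no ring), on a saturated chain carbon bound to an aromatic carbon. The rest of the structure is the same, so any shift in this assay falls on that single exchange. Among the measured compounds shown here, no measured pair in the set shares this exchange, so nothing in the data fixes its size.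

The account therefore rests on an expectation only. Compound 3 is expected to give a lower number than compound 2, with a step from compound 2 to compound 3 of about a 2.8-fold lower number from compound 2 to compound 3 (0.45 log units; beyond the scatter), a modest move rather than a large one. On that basis compound 3 is estimated at 5000 nM in this assay, within a range from 1500 nM to 15000 nM.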

Compound 3, concentration for 50% growth inhibition: 59900 nM
Estimate against measurement, compound 3: 12-fold (1.08 log units) below; measured number outside the range, above it.
By their numbers in this assay, from the lowest: compound 1; then compound 2; then compound 3.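

The exchange of the cyanosulfanyl group for its selenium counterpart, on a saturated chain carbon bound to an aromatic carbon, now has a measured direction and size: in this assay the step is a 4.2-fold higher number from compound 2 to compound 3 (0.63 log units; beyond the scatter) and it makes compound 3 the weaker inhibitor of growth of that pair. The earlier compounds shown here could not show this, as no measured pair carried the exchange; it now appears that this position responds to a change of a single atom, sulfur to selenium, while the rest of the structure stays the same. Nothing in the data given accounts for the direction or size of this step.

Among the compounds shown here, compound 2 and compound 3 are the only pair with this exchange, so whether it runs the same way on any other core remains open. Also open, from the compounds shown here alone, is how the number in this assay would respond if a group other than these two stood at this position, such as an amine, a carboxylic acid or a longer chain ending in the nitrile.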